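A Bromophenyl Exchange on Compound 2

A few compounds are considered here, and "the series" means these few. Any claim that something is new, unique, unknown or untested is made for them only; others in the source may bear on it.

Among the compounds with values here, only two measurements are available so far. In a functional assay on HCT-116 cells (Homo sapiens) for antiproliferative activity, read by sulforhodamine B assay, with a stated time of 48 h (a higher number here means a weaker inhibitor, a lower number a stronger inhibitor), compound 1 (`COc1cccc(/C=C/C(=O)c2c(O)cc(OC)cc2OC)c1`) gives 3100 nM and compound 2 (`COc1cc(OC)c(C(=O)/C=C/c2ccc(OC)c(OC)c2)c(OCC=C(C)C)c1`) gives 5700 nM so compound 2 stands within the scatter of compound 1. These two compounds differ in more than one place, which makes their closeness only a loose guide. Compound 3 (`COc1cc(OC)c(C(=O)/C=C/c2ccc(Br)cc2)c(OCC=C(C)C)c1`) departs from compound 2 by a single exchange (4-bromophenyl in place of 3,4-dimethoxyphenyl on a double-bonded chain carbon bound to a double-bonded chain carbon) with 4-bromophenyl in place of 3,4-dimethoxyphenyl on a double-bonded chain carbon bound to a double-bonded chain carbon. Within the data shown here, no measured pair shows this exchange on its own, so no change beyond the scatter is expected in this assay in either direction. The estimated move is a 1.3-fold lower number from compound 2 to compound 3 (0.10 log units; within the scatter) and it stays within the scatter. For compound 3 the estimate is 4500 nM with an expected range from 1800 nM to 12000 nM as its upper end.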

Compound 3, half-maximal inhibitory concentration: 2100 nM
Compound 3: the middle estimate sits 2.1-fold (0.33 log units) above what was measured, and the stated range covers the measured number.
By their numbers in this assay, from the lowest: compounds 3, 1 and 2 (each within the scatter of the next, the first and the last beyond it).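

In this assay, within the data shown here, 4-bromophenyl in place of 3,4-dimethoxyphenyl on a double-bonded chain carbon bound to a double-bonded chain carbon gives a 2.7-fold lower number from compound 2 to compound 3 (0.43 log units; beyond the scatter), a modest step and the first comparison here of compounds that differ in one place. It shows that the read-out responds to the group at this place, and that a group with 0 hydrogen-bond acceptors can stand where one with 2 stood without the number rising. No measurement at hand bears on why the number falls with this exchange.

A single step cannot separate the departure of the two methoxy groups from the arrival of the bromine, so either could underlie the change. The compounds shown also leave open how a 4-aminophenyl or a 4-carboxyphenyl group would read at this place.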